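Adding a methoxy group to two caffeic-type hydrazides

The source may hold more compounds than are shown below. What is called first, only, known or untested is meant among the compounds shown, and "the series" means these compounds.

Compound 1 `O=C(/C=C/c1ccc(O)c(O)c1)NNC(=O)c1ccccc1` and compound 2 `COc1ccc(C(=O)NNC(=O)/C=C/c2ccc(O)c(O)c2)cc1` share one core; compound 3 `COc1cc(/C=C/C(=O)NNC(=O)c2ccccc2)cc(OC)c1O` and the not yet measured compound 4 `COc1ccc(C(=O)NNC(=O)/C=C/c2cc(OC)c(O)c(OC)c2)cc1` share another, and the difference between the two cores is not broken down here. In a functional assay on MCF7 cells (Homo sapiens) for antiproliferative activity, read by MTT assay, with a stated time of 24 h (a higher number here means a weaker inhibitor, a lower number a stronger inhibitor), compound 1 gives 4750 nM. In this assay compound 2 gives 4860 nM. The change between them, (methoxy in place of hydrogen on an aromatic carbon), made a step of a 1.0-fold higher number from compound 1 to compound 2 (0.01 log units; within the scatter). For compound 3, this assay reports only a limit, > 10000 nM, as noted in the limit of > 10000 nM in this assay, at which 1 of the 3 values shown sits. The same change, (methoxy in place of hydrogen on an aromatic carbon), turns compound 3 into compound 4. Since the step from compound 1 to compound 2 was a 1.0-fold higher number from compound 1 to compound 2 (0.01 log units; within the scatter), compound 4 is expected to move little, a step that the limit leaves unreadable from compound 3 to compound 4 from compound 3, and most likely to remain at a limit. The estimate for compound 4 in this assay is therefore 12000 nM, between 6000 nM and 40000 nM.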

Compound 4, half-maximal inhibitory concentration: 7170 nM
Beside the measured number, compound 4's estimate is 1.7-fold (0.22 log units) above it; measured number inside the range.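

On the second core, the change from phenyl to 4-methoxyphenyl gives an at least 1.3-fold lower number from compound 3 to compound 4 (0.14 log units; that floor lies within the scatter) in this assay. Set beside the same change on the first core, this step is only partly readable: the same change on two cores in this assay, a 1.0-fold higher number (0.01 log units; within the scatter) from compound 1 to compound 2 and an at least 1.3-fold lower number (0.14 log units; that floor lies within the scatter) from compound 3 to compound 4; the limit leaves it open whether they differ The result therefore shows neither that the change carries over unchanged from one core to the other nor that it acts differently, since compound 3 is known only as a limit: the limit of > 10000 nM in this assay, at which 1 of the 4 values shown sits.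

The compounds shown leave open how the step would compare if compound 3 had an exact number. They also leave open what an amine or a carboxylic acid in place of the methoxy group would do on either core.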